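The source may hold more compounds than are shown below. What is called first, only, known or untested is meant among the compounds shown, and "the series" means these compounds.

Measured so far:
compound 1, `CC(=O)Oc1ccc(C(=O)Nc2cc3ccc(OCC4CCCNC4)c(C)c3oc2=O)cc1CC=C(C)C`, 820 nM
compound 2, `CC(C)=CCc1cc(C(=O)Nc2cc3ccc(OCC4CCN(C)C4)c(C)c3oc2=O)ccc1O`, 1550 nM

Of the compounds shown here, two share a core and have been tested in a functional assay on MCF7 cells (Homo sapiens) for antiproliferative activity; a higher number here means a weaker inhibitor, a lower number a stronger inhibitor. Compound 1 gives 820 nM. Compound 2 gives 1550 nM. These two values sit within the scatter of each other, so compound 2 cannot be set apart from compound 1 on the numbers shown; neither compound can be called the stronger or the weaker.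

Compound 3, `CC(C)=CCc1cc(C(=O)Nc2cc3ccc(OCCCN(C)C(C)C)c(C)c3oc2=O)ccc1O`, has not yet been measured in this assay. It differs from compound 2 in one place:
2-(isopropyl(methyl)amino)ethyl in place of 1-methylpyrrolidin-3-yl on a saturated chain carbon bound to an oxygen on an aromatic ring
For the measured compounds named here, no step between measured compounds bears on this change, so nothing measured tells how it will read. The change keeps one hydrogen-bond acceptor and no donor and trades a ring for a chain of similar size. The expectation is that the step of a 1.0-fold lower number from compound 2 to compound 3 (0.01 log units; within the scatter) stays within the scatter, with no clear direction. Compound 3 is therefore estimated at 1500 nM, with a range from 600 nM to 4000 nM.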

Compound 3, half-maximal inhibitory concentration: 1050 nM
Compound 3: middle estimate off by 1.4-fold (0.15 log units), on the high side; low and high end bracket the measured number.
By their numbers in this assay, from the lowest: compounds 1, 3 and 2 (each within the scatter of the next).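

In this assay, putting 2-(isopropyl(methyl)amino)ethyl in place of 1-methylpyrrolidin-3-yl on a saturated chain carbon bound to an oxygen on an aromatic ring gives a 1.5-fold lower number from compound 2 to compound 3 (0.17 log units; within the scatter) and so cannot be told apart from repeat measurement. For this pair, the five-membered non-aromatic ring is therefore not needed to keep the reading in the same range, and an open chain carrying its nitrogen serves alike. Nothing shown explains why the two groups read alike.

The compounds shown leave open whether the nitrogen itself matters at this place, which a plain butyl chain or a carboxylic acid in its stead would test. They also leave open how a morpholine ring or a longer chain carrying the same amine would read.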